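The source may hold more compounds than are shown below. What is called first, only, known or untested is meant among the compounds shown, and "the series" means these compounds.

In an ADME assay on KB cells (Homo sapiens) for cytotoxicity, read by MTT assay, with a stated time of 72 h (on this read-out lower numbers stand for stronger inhibition and higher numbers for weaker inhibition), compound 1 (`COc1ccc(C2=C(c3cc(OC)c(OC)c(OC)c3)C(=O)CC2O)cc1O`) reads < 1 ug/mL, which is a limit and not a number. Compound 2 (`COc1ccc(C2=C(c3cc(OC)c(OC)c(OC)c3)C(=O)CC2O)cc1`) has the entry "not determined" (no result reported), so it gives no comparison. Compound 3 (`COc1ccc(C2=C(c3cc(OC)c(OC)c(OC)c3)C(=O)CC2O[SiH2]C(C)(C)C)cc1O`) keeps the core of compound 1 and changes in one place: a group of 5 heavy atoms (4 carbon, 1 silicon; no ring) in place of a hydrogen atom, on an oxygen on a saturated carbon. The new group of 5 heavy atoms, with no ring, sits on an oxygen on a saturated carbon. No measured pair sizes this change, so only a modest move toward weaker inhibition is expected, with an expected step that the limit leaves unreadable from compound 1 to compound 3 in this assay. For compound 3 the estimate is 0.6 ug/mL, with an expected range of 0.08 ug/mL to 5 ug/mL.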

Compound 3, half-maximal inhibitory concentration: 6.5 ug/mL
Beside the measured number, compound 3's estimate is 11-fold (1.03 log units) below it, and the stated range ends below it.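

On an oxygen on a saturated carbon, a group of 5 heavy atoms (4 carbon, 1 silicon; no ring) in place of a hydrogen atom gives, in this assay, an at least 6.5-fold higher number from compound 1 to compound 3 (0.81 log units; beyond the scatter). This position therefore does not tolerate every change without a shift in the read-out. The true size of the step stays unknown because the value of compound 1 is a limit: the limit of < 1 ug/mL in this assay, at which 1 of the 3 values shown sits.

As far as these compounds go, whether the shift follows from the hydrogen atom leaving or from this particular group entering stays open. A methyl or an acetyl on the same oxygen would separate the two.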